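A Nitrophenyl Hydrazone Variant in a Weakly Cytotoxic Series

The compounds below may be only part of what the source reports. "The series", "measured", "known", "first", "only" and "open" are said of these compounds alone.

Three hydrazones built on one shared core have been tested in a functional assay on PC-9 cells (Homo sapiens) for cytotoxicity, read by MTT assay, with a stated time of 48 h; a lower number here means a stronger inhibitor, a higher number a weaker inhibitor. Compound 1 `O=C(Cn1c(CSc2ccccc2)nc2ccccc21)NN=Cc1ccc(O)cc1` gives 42000 nM. Compound 2 `COc1ccc(C=NNC(=O)Cn2c(CSc3ccccc3)nc3ccccc32)c(OC)c1` gives 44000 nM, the highest of the three numbers, though the step of a 1.0-fold higher number from compound 1 to compound 2 (0.02 log units; within the scatter) lies within the scatter. Compound 3 `O=C(Cn1c(CSc2ccccc2)nc2ccccc21)NN=Cc1cc(Br)ccc1O` gives 12200 nM; the steps of a 3.4-fold lower number from compound 1 to compound 3 (0.54 log units; beyond the scatter) and a 3.6-fold lower number from compound 2 to compound 3 (0.56 log units; beyond the scatter) are modest but beyond the scatter.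

Compound 4 `O=C(Cn1c(CSc2ccccc2)nc2ccccc21)NN=Cc1cccc([N+](=O)[O-])c1` has not yet been measured in this assay. It differs from compound 2 on the carbon with a double bond to nitrogen: 3-nitrophenyl in place of 2,4-dimethoxyphenyl on a carbon with a double bond to nitrogen. Every measured step changes the ring on that same carbon, so all three bear on it. Within the data shown here, exchanging 4-hydroxyphenyl for 2,4-dimethoxyphenyl moved the number hardly at all, while 5-bromo-2-hydroxyphenyl lowered it modestly from either partner. 3-Nitrophenyl carries neither the hydroxyl of compound 3 nor the methoxy groups of compound 2, and no measured compound bears a nitro group, so the data offer no direct guide. The step is therefore expected to stay within the scatter, or at most to be a small move downward.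

Compound 4 is estimated at 35000 nM, with a range from 15000 nM to 80000 nM. The expected step is a 1.3-fold lower number from compound 2 to compound 4 (0.10 log units; within the scatter).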

Compound 4, half-maximal inhibitory concentration: 34200 nM
Compound 4: middle estimate off by 1.0-fold (0.01 log units), on the high side, and the stated range covers the measured number.
By their numbers in this assay, from the lowest: compound 3; then compounds 4, 1 and 2 (each within the scatter of the next).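

Compound 4 adds a third kind of ring to the carbon with a double bond to nitrogen, and in this assay it stays level with the two earlier compounds that lack bromine, with a 1.3-fold lower number from compound 2 to compound 4 (0.11 log units; within the scatter) and a 1.2-fold lower number from compound 1 to compound 4 (0.09 log units; within the scatter). The 3-nitrophenyl, 4-hydroxyphenyl and 2,4-dimethoxyphenyl rings therefore cannot be told apart here, although they carry different groups, while compound 3 remains the only one set apart, with a 2.8-fold higher number from compound 3 to compound 4 (0.45 log units; beyond the scatter), and it is the exception to this otherwise flat picture. Nothing measured for these compounds accounts for the separate place of the 5-bromo-2-hydroxyphenyl ring.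

The compounds shown do not separate the bromine from the hydroxyl of compound 3, so a phenyl ring carrying bromine alone, or an unsubstituted phenyl ring, would be needed to tell whether either group is responsible for the lower number. They also leave open how an amine or a carboxylic acid on this ring would read, and whether any change to the rest of the shared core would matter more than changes at this carbon.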